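From an Inactive Acid to a Chlorinated Amide

A few compounds are considered here, and "the series" means these few. Any claim that something is new, unique, unknown or untested is made for them only; others in the source may bear on it.

compound 1 `O=C(O)CCCCC(CCSC(=O)c1ccccc1)SC(=O)c1ccccc1`: "not active" (no number reported)
compound 2 `COc1ccc(NC(=O)CCCCC(S)CCS)cc1`: 1.43%
compound 3 `CC(=O)SCCC(CCCCC(=O)Nc1ccccc1)SC(C)=O`: 14.2%
compound 4 `O=C(CCCCC(CCSC(=O)c1ccccc1)SC(=O)c1ccccc1)Nc1ccccc1Cl`: not yet measured

In a functional assay on NCI-H460 cells (Homo sapiens) for inhibition, read by MTT assay, with a stated time of 24 h, tested at 10 ug/mL (a higher number here means more inhibition of growth at the concentration tested, a lower number less inhibition of growth), compound 1 has no number ("not active" (no number reported)), so it gives no baseline from which to count. The step (2-chlorophenyl)amino in place of hydroxy on a carbonyl carbon puts (2-chlorophenyl)amino in place of hydroxy on a carbonyl carbon, turning the acid into an amide. The size of this step cannot be calculated, but a modest rise in growth inhibition is expected. The other two amides, compound 2 (1.43%) and compound 3 (14.2%), give only low readings, so a large jump is not expected. For compound 4 the inhibition is estimated at 18% (expected range 3% to 45%).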

Compound 4, percent growth inhibition at one concentration: 12.1%
Compound 4: the middle estimate sits 5.9 percentage points above what was measured; the range from low to high includes it.
By their numbers in this assay, from the lowest: compound 2; then compounds 4 and 3 (each within the scatter of the next).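

Among these compounds, compound 1 gives "not active" (no number reported) in this assay, so no step to compound 4 can be read. On these data alone, whether (2-chlorophenyl)amino in place of hydroxy changes growth inhibition stays open. No measurement shown offers an explanation.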